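The source may report more compounds than this note shows. Statements on the series, on what has been measured and on what is new or still open speak of the compounds shown alone.

Measured so far in a functional assay on HepG2 cells (Homo sapiens) for inhibition, read by MTT assay, with a stated time of 48 h; a lower number here means a stronger inhibitor, a higher number a weaker inhibitor
Compound 1 `Fc1ccc(/C=N/Nc2nc(-c3ccc(F)c(F)c3)cs2)cc1F` gives 26600 nM
Compound 2 `COc1cc(/C=N/Nc2nc(-c3ccc(F)c(F)c3)cs2)c(Br)c(Br)c1OC` gives 49700 nM

These two values lie within the scatter of each other, so compound 1 cannot be told apart from compound 2. Compound 3 `Fc1ccc(/C=N/Nc2nc(-c3ccccc3)cs2)cc1F` carries phenyl in place of 3,4-difluorophenyl on an aromatic carbon and has not yet been measured. For the measured compounds named here, no measured pair shows this change, so the expectation starts from compound 1 (26600 nM) and the structural change alone. In this assay no step beyond the scatter is expected, and the estimated step is small (a 1.1-fold higher number from compound 1 to compound 3 (0.05 log units; within the scatter)). Compound 3 is estimated at 30000 nM within an expected range (11000 nM to 80000 nM).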

Compound 3, half-maximal inhibitory concentration: > 100000 nM
Compound 3: a limit, no number; the forecaster's own chance of this, stated with the estimate: 10%; middle value at least 3.3-fold (0.52 log units) away from the limit.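

In this assay, the 3,4-difluorophenyl on the aromatic carbon next to the ring nitrogen proves not to be interchangeable with phenyl, which gives an at least 3.7-fold higher number from compound 1 to compound 3 (0.57 log units; beyond the scatter). Compound 1 and compound 2 share this group, so only compound 3 exposes the position to change. The reading of compound 3 is a limit of the assay and not a number: the limit of > 100000 nM in this assay, at which 1 of the 3 values shown sits.

From the compounds shown here alone, the true size of the step therefore stays open. The compounds shown also leave open whether a single fluorine, a chlorine or a trifluoromethyl group on this phenyl would keep the value of compound 1.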